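The source may hold more compounds than are shown below. What is called first, only, known or untested is meant among the compounds shown, and "the series" means these compounds.

Of the compounds shown here, three built on one shared core have been tested in a functional assay on A-431 cells (Homo sapiens) for cytotoxicity, read by MTT assay, with a stated time of 24 h; a higher number here means a weaker inhibitor, a lower number a stronger inhibitor. Compound 2 `COc1ccccc1-n1cc(COc2c(/C=C\C(=O)O)ccc(OC)c2CC=C(C)C)nn1` gives 32600 nM; this is the largest of the three numbers, yet both of the others sit within the usual scatter of it, so no ordering among them is secure. Compound 1 `COc1ccc(/C=C\C(=O)O)c(OCc2cn(-c3ccc(NC(C)=O)cc3)nn2)c1CC=C(C)C` gives 23400 nM and compound 3 `COc1ccc(/C=C\C(=O)O)c(OCc2cn(-c3cccc([N+](=O)[O-])c3)nn2)c1CC=C(C)C` gives 18400 nM. Each step between these compounds changes only the group on the aromatic nitrogen, and none moves the number beyond the scatter: a 1.4-fold higher number from compound 1 to compound 2 (0.14 log units; within the scatter), a 1.3-fold lower number from compound 1 to compound 3 (0.10 log units; within the scatter), a 1.8-fold lower number from compound 2 to compound 3 (0.25 log units; within the scatter). Compound 4 `COc1ccc(/C=C\C(=O)O)c(OCc2cn(-c3ccccc3C#N)nn2)c1CC=C(C)C` differs from compound 2 by cyano in place of methoxy on an aromatic carbon. From those three small steps, the expected change is a 1.2-fold lower number from compound 2 to compound 4 (0.07 log units; within the scatter), nothing beyond the scatter. Compound 4 is therefore estimated at 28000 nM, with a range from 14000 nM to 56000 nM.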

Compound 4, half-maximal inhibitory concentration: 10300 nM
Estimate against measurement, compound 4: 2.7-fold (0.43 log units) above, and the stated range ends above it.
By their numbers in this assay, from the lowest: compounds 4, 3, 1 and 2 (each within the scatter of the next, the first and the last beyond it).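

For the compounds shown here, this is the first change on this ring to go beyond the scatter: cyano in place of methoxy, ortho to a large group, gives a modest step (a 3.2-fold lower number from compound 2 to compound 4 (0.50 log units; beyond the scatter)), and replacing 4-acetamidophenyl with 2-cyanophenyl also gives a modest step beyond it (a 2.3-fold lower number from compound 1 to compound 4 (0.36 log units; beyond the scatter)). Against 3-nitrophenyl, however, 2-cyanophenyl stays within the scatter (a 1.8-fold lower number from compound 3 to compound 4 (0.25 log units; within the scatter)), so it stands apart from only two of the three earlier groups. Nothing available explains the shift.

From the compounds shown here alone, what an amine, a fluorine or a longer chain would do in place of the cyano group remains open. So does whether cyano would give a similar step elsewhere on this ring.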